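The source may hold more compounds than are shown below. What is called first, only, known or untested is meant among the compounds shown, and "the series" means these compounds.

Among the compounds with values here, compound 1 `ClCc1cccc(Cn2cnc3nc(Cl)nc(Cl)c32)c1` is one of two compounds measured in a functional assay on HOP-62 cells (Homo sapiens) for cytotoxicity, read by sulforhodamine B assay, with a stated time of 48 h; on this read-out lower numbers stand for stronger inhibition of growth and higher numbers for weaker inhibition of growth; in this assay compound 1 gives 2180 nM. Its companion, compound 2 `ClCc1ccccc1Cn1cnc2c(Cl)nc(Cl)nc21`, gives 2040 nM in this assay, and the two numbers lie within the scatter of each other, so no order between them can be read. Compound 3 `ClCc1cccc(Cn2cnc3ncnc(Cl)c32)c1` has not been measured; it differs from compound 1 in one place: hydrogen in place of chloro on an aromatic carbon. Within the data shown here, no measured pair shows what such a change does here, so the expected step from compound 1 to compound 3, a 1.6-fold higher number from compound 1 to compound 3 (0.21 log units; within the scatter), is a modest loss of potency, hardly beyond the scatter. Compound 3 is expected to give about 3500 nM in this assay, within a range of 1500 nM to 9000 nM.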

Compound 3, concentration for 50% growth inhibition: 2180 nM
Compound 3: middle estimate off by 1.6-fold (0.21 log units), on the high side; the range from low to high includes it.
By their numbers in this assay, from the lowest: compounds 2, 1 and 3 (each within the scatter of the next).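

Hydrogen in place of chloro gives no change at the digits printed from compound 1 to compound 3 (within the scatter) in this assay and so is the first one-place comparison here: on an aromatic carbon between two ring nitrogen atoms, chloro and hydrogen cannot be told apart by this read-out. This pair alone carries that finding, and nothing at hand explains it. From the compounds shown here alone, what an amine or a methoxy group would do at this position stays open, and so does the effect of replacing the remaining chloro or the chloromethyl group.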